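Swapping a para ethyl for chloro(difluoro)methoxy

This account rests on a few compounds, and the source may have more. Where it says the series, first, only, none or still open, it means among the compounds named here.

Of the compounds shown here, three sharing one core have been measured in an assay on mitochondria from L6 cells (Rattus norvegicus) for activation, with a stated time of 90 min; a lower number here means that less compound is needed, a higher number that more compound is needed for the effect. Compound 1 `Oc1nc2nonc2nc1Nc1cccc2ccccc12` gives 20400 nM. Compound 2 `CCc1ccc(Nc2nc3nonc3nc2O)cc1` gives 10700 nM. Compound 3 `Cc1cc(C)c(Nc2nc3nonc3nc2O)c(C)c1` gives 113000 nM. Among these three numbers compound 2 has the lowest one; compound 1 lies within the usual scatter of it, so the two cannot be ranked against each other, while compound 3 sits well beyond the scatter with a clearly higher number.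

The compound not yet measured is compound 4 `Oc1nc2nonc2nc1Nc1ccc(OC(F)(F)Cl)cc1`. It differs from compound 2 in one place: chloro(difluoro)methoxy in place of ethyl on an aromatic carbon. Among the measured compounds shown here, no measured pair in this set shows the effect of such a change, so the expectation rests only on the standing of compound 2 and on the size of the group that enters.

Because compound 2 already gives 10700 nM, the estimated step of a 1.8-fold lower number from compound 2 to compound 4 (0.25 log units; within the scatter) is expected to be small and towards a lower number, close to the edge of the scatter rather than clearly beyond it. On that basis the value expected for compound 4 in this assay is 6000 nM, with a likely range from 2000 nM to 20000 nM.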

Compound 4, half-maximal effective concentration: 1900 nM
The estimate for compound 4 lay 3.2-fold (0.50 log units) above the measured number, outside the stated range (below it).
By their numbers in this assay, from the lowest: compound 4; then compounds 2 and 1 (each within the scatter of the next); then compound 3.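

In this assay, among the compounds shown here, chloro(difluoro)methoxy in place of ethyl gives a 5.6-fold lower number from compound 2 to compound 4 (0.75 log units; beyond the scatter), a step beyond the usual scatter and the first change in a single place that can be read in this set. It shows that the group on this aromatic carbon, para to a large group, matters for how much compound is needed, and that the larger group entering here, with 5 heavy atoms against 2 and 1 hydrogen-bond acceptor where ethyl has 0, comes with a lower number rather than a higher one. No measurement shown here explains why the number falls, so the step stands as an observation only.

From the compounds shown here alone, what remains open is which part of the new group goes with the change: methoxy, trifluoromethyl or a single chlorine atom at the same position would help to separate the oxygen from the halogens. Going by these compounds, it is also open whether a longer chain, an amine or a carboxylic acid would be accepted here, and whether chloro(difluoro)methoxy would give a similar step on another compound.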